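The source may hold more compounds than are shown below. What is called first, only, known or untested is meant among the compounds shown, and "the series" means these compounds.

Measured compounds:
compound 1 `CC1(C)Cc2c(sc(NC(=O)C3CCNC3=O)c2C(N)=O)C(C)(C)O1` gives 101 nM in an assay on cells for positive allosteric modulation of Cystic fibrosis transmembrane conductance regulator variant F508del (Homo sapiens), with stated times of 10 min and 7 s, in the presence of a further agent that is not named here; on this read-out lower numbers stand for an effect already at smaller amounts and higher numbers for an effect only at larger amounts of compound;
compound 2 `Cc1cn[nH]c1C(=O)Nc1sc2c(c1C(N)=O)CC(C)(C)OC2(C)C` gives 2 nM in this assay.

Within the data shown here, compound 2 stands at the lowest of the two numbers; the single step from it, a 51-fold lower number from compound 1 to compound 2 (1.70 log units; beyond the scatter), was large. Compound 3 `Cc1n[nH]c(C(=O)Nc2sc3c(c2C(N)=O)CC(C)(C)OC3(C)C)c1Cl` differs from compound 2 by a group of 7 heavy atoms (4 carbon, 2 nitrogen, 1 chlorine; one five-membered aromatic ring with 2 hetero atoms) in place of a group of 6 heavy atoms (4 carbon, 2 nitrogen; one five-membered aromatic ring with 2 hetero atoms), on a carbonyl carbon. Among the measured compounds shown here, no measured step addresses this kind of change; the one step known, a 51-fold lower number from compound 1 to compound 2 (1.70 log units; beyond the scatter), exchanged the whole group rather than adding a chlorine to it, so it bears only loosely. Compound 3 is therefore expected to show no step beyond the scatter, no change at the digits printed from compound 2 to compound 3 (within the scatter), with an estimated 2 nM ranging from 0.5 nM to 8 nM.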

Compound 3, half-maximal effective concentration: 11 nM
The estimate for compound 3 lay 5.5-fold (0.74 log units) below the measured number; measured number above the stated range.
By their numbers in this assay, from the lowest: compound 2; then compound 3; then compound 1.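

At this carbonyl carbon, two five-membered aromatic rings with 2 hetero atoms do not read alike in this assay: the group with 7 heavy atoms, chlorine among them, in place of 4-methyl-1H-pyrazol-5-yl gives a 5.5-fold higher number from compound 2 to compound 3 (0.74 log units; beyond the scatter). This group still stands apart from 2-oxopyrrolidin-3-yl, with a 9.2-fold lower number from compound 1 to compound 3 (0.96 log units; beyond the scatter). No measurement shown explains the loss against 4-methyl-1H-pyrazol-5-yl. The compounds shown leave open how much of the step belongs to the chlorine itself, and how a ring carrying a nitrile or a trifluoromethyl instead of chlorine would read.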